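Urea series: nitro in place of iodo, expected dose

The source may hold more compounds than are shown below. What is called first, only, known or untested is meant among the compounds shown, and "the series" means these compounds.

Measured compounds:
- compound 1, `Cc1cccc(C)c1NC(=O)Nc1ccncc1`: 30 mg/kg
- compound 2, `O=C(Nc1ccncc1)Nc1ccccc1O`: > 300 mg/kg
- compound 3, `O=C(Nc1ccncc1)Nc1ccc(I)cc1`: > 300 mg/kg

For the measured compounds named here, in a functional assay on the whole organism with Mus musculus as the target, in the maximal electroshock model, with a stated time of 30 min (a higher number here means that more compound is needed for the effect, a lower number that less compound is needed), compound 1 gives 30 mg/kg, the only numerical value in the set. For compound 2 the result is a limit of the assay, > 300 mg/kg. Compound 3 likewise reaches only (the limit of > 300 mg/kg in this assay, at which 2 of the 3 values shown sit), so for compound 3 the result is also a limit of the assay, > 300 mg/kg; it stands with compound 2 at the edge of the assay and apart from compound 1, whose number lies well inside the range.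

The next compound is compound 4, `O=C(Nc1ccncc1)Nc1ccc([N+](=O)[O-])cc1`. It differs from compound 3 by nitro in place of iodo on an aromatic carbon.

Going by the values given here, no step between two measured compounds exists to calibrate this exchange. Since compound 3 sits at the limit, the step from compound 3 to compound 4 is expected to be small or absent, a number no higher from compound 3 to compound 4 (the limit leaves the size open), with the result most likely a limit again. The estimate for compound 4 in this assay is 300 mg/kg, between 100 mg/kg and 900 mg/kg.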

Compound 4, minimum effective dose: > 300 mg/kg
Compound 4 ended at the assay's limit (the forecaster's own chance of this, stated with the estimate: 65%); the middle value sits exactly at the limit.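

For the compounds shown here, compound 4, like compound 3, ends at a limit of the assay, and no step between the two can be read: the limit of > 300 mg/kg in this assay, at which 3 of the 4 values shown sit. The compounds shown leave open how far either lies past that limit, and whether nitro in place of iodo changes the dose at all.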